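A few compounds are considered here, and "the series" means these few. Any claim that something is new, unique, unknown or untested is made for them only; others in the source may bear on it.

Compound 2 `COc1ccc(C(=O)c2cc(OC)c(OC)c(OC)c2)cc1NC(=O)/C=C/c1cccc(OC(F)(F)F)c1` and compound 1 `COc1ccc(/C=C/C(=O)Nc2cc(C(=O)c3cc(OC)c(OC)c(OC)c3)ccc2OC)cc1` share one core and differ only in the aryl group on a double-bonded chain carbon bound to a double-bonded chain carbon. In a functional assay on B16 cells (Mus musculus) for cytotoxicity, read by MTT assay, with a stated time of 72 h (on this read-out lower numbers stand for stronger inhibition and higher numbers for weaker inhibition), compound 2 gives 6300 nM, the lower of the two numbers shown, and compound 1 gives 8700 nM, so the two lie within the scatter of each other. Among the compounds with values here, the only measured step at this position, a 1.4-fold lower number from compound 1 to compound 2 (0.14 log units; within the scatter), brought no change beyond that scatter. Compound 3 `COc1ccc(C(=O)c2cc(OC)c(OC)c(OC)c2)cc1NC(=O)/C=C/c1ccc(N)cc1` carries 4-aminophenyl in place of 3-(trifluoromethoxy)phenyl on a double-bonded chain carbon bound to a double-bonded chain carbon. Within the data shown here, because the one comparable step a 1.4-fold lower number from compound 1 to compound 2 (0.14 log units; within the scatter) stayed within the scatter, the step of a 1.1-fold higher number from compound 2 to compound 3 (0.05 log units; within the scatter) is expected to be small. Compound 3 is therefore estimated at 7000 nM, within a range from 2500 nM to 20000 nM.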

Compound 3, half-maximal inhibitory concentration: 7900 nM
Estimate against measurement, compound 3: 1.1-fold (0.05 log units) below; the measured number falls inside the stated range.
By their numbers in this assay, from the lowest: compounds 2, 3 and 1 (each within the scatter of the next).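

The step to 4-aminophenyl, a 1.3-fold higher number from compound 2 to compound 3 (0.10 log units; within the scatter), and the step of amino in place of methoxy on an aromatic carbon, a 1.1-fold lower number from compound 1 to compound 3 (0.04 log units; within the scatter), both stay inside the usual spread in this assay. So three aryl groups at this position, one of them now carrying a hydrogen-bond donor, cannot be told apart by this read-out. Nothing measured here offers an explanation for this.

As far as these compounds go, whether a carboxylic acid, a nitrile or a longer chain on that aromatic ring would move the number beyond the scatter remains open.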